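The source may report more compounds than this note shows. Statements on the series, on what has been measured and on what is new or still open speak of the compounds shown alone.

Measured in a functional assay on SGC-7901 cells (Homo sapiens) for inhibition, read by MTT assay, with a stated time of 24 h; on this read-out lower numbers stand for stronger inhibition and higher numbers for weaker inhibition:
Compound 1 `CC1(C)[C@H]2CC[C@]1(C)N(Cc1cn(-c3ccc(C#N)cc3)nn1)C(=O)C2`: 500 nM
Compound 2 `CC1(C)[C@H]2CC[C@]1(C)N(Cc1cn(-c3ccccc3Cl)nn1)C(=O)C2`: 220 nM
Compound 3 `CC1(C)[C@H]2CC[C@]1(C)N(Cc1cn(-c3cccc(Cl)c3)nn1)C(=O)C2`: 510 nM

Compound 3 gives 510 nM. The data show a 1.0-fold higher number from compound 1 to compound 3 (0.01 log units; within the scatter), and also a 2.3-fold higher number from compound 2 to compound 3 (0.37 log units; beyond the scatter), so only compound 2 stands clearly apart.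

Compound 4 `COc1ccccc1-n1cc(CN2C(=O)C[C@@H]3CC[C@@]2(C)C3(C)C)nn1` carries 2-methoxyphenyl in place of 3-chlorophenyl on an aromatic nitrogen. The closest guide is the modest step between the two chlorophenyl compounds, read backwards: compound 2, with its 2-chlorophenyl group, gives 220 nM. Among the measured compounds shown here, no methoxy compound has been measured, so only part of that step is expected to carry over, towards a lower number in this assay. The estimated move is a 1.7-fold lower number from compound 3 to compound 4 (0.23 log units; within the scatter). For compound 4 the expected value is 300 nM, with an estimated range from 120 nM to 700 nM.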

Compound 4, half-maximal inhibitory concentration: 280 nM
Estimate against measurement, compound 4: 1.1-fold (0.03 log units) above; low and high end bracket the measured number.
By their numbers in this assay, from the lowest: compounds 2, 4, 1 and 3 (each within the scatter of the next, the first and the last beyond it).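

In this assay, methoxy in place of chloro on the aromatic carbon gives a 1.3-fold higher number from compound 2 to compound 4 (0.10 log units; within the scatter) and so shows that these two groups cannot be told apart here. Compound 4 also cannot be separated from the other two compounds, with a 1.8-fold lower number from compound 3 to compound 4 (0.26 log units; within the scatter) and a 1.8-fold lower number from compound 1 to compound 4 (0.25 log units; within the scatter) as the steps, even though compound 2 and compound 3 differ beyond the scatter. No measured evidence here accounts for these results. The compounds shown leave open how the series would respond to an amine or a carboxylic acid in place of the methoxy group.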